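Taking One Chloro Away From Compound 3

A few compounds are considered here, and "the series" means these few. Any claim that something is new, unique, unknown or untested is made for them only; others in the source may bear on it.

Values in a functional assay on HL-60 cells (Homo sapiens) for antiproliferative activity, read by MTT assay, with a stated time of 72 h; a higher number here means a weaker inhibitor, a lower number a stronger inhibitor:
Compound 1 `NC1=NC2(CCOCC2)N(OCCCOc2ccc(Cl)cc2)C(N)=N1` gives 330 nM
Compound 2 `NC1=NC2(CCOCC2)N(OCCCOc2cccc(Cl)c2Cl)C(N)=N1` gives 440 nM
Compound 3 `NC1=NC2(CCOCC2)N(OCCCOc2ccc(Cl)c(Cl)c2)C(N)=N1` gives 1240 nM

Compound 3 stands highest of the three, with both gaps beyond the scatter: a 3.8-fold higher number from compound 1 to compound 3 (0.57 log units; beyond the scatter) and a 2.8-fold higher number from compound 2 to compound 3 (0.45 log units; beyond the scatter) in turn. Compound 4 `NC1=NC2(CCOCC2)N(OCCCOc2cccc(Cl)c2)C(N)=N1` is unmeasured and differs from compound 3 thus: hydrogen in place of chloro on an aromatic carbon, which turns 3,4-dichlorophenyl into 3-chlorophenyl. The closest measured change is the chloro added to compound 1, a 3.8-fold higher number from compound 1 to compound 3 (0.57 log units; beyond the scatter), a modest step, and here a chloro leaves instead. A modest fall is therefore expected, namely a 2.3-fold lower number from compound 3 to compound 4 (0.35 log units; beyond the scatter) as an estimate. Compound 4 is estimated at 550 nM in this assay, with an expected range from 230 nM to 1200 nM.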

Compound 4, half-maximal inhibitory concentration: 520 nM
Estimate against measurement, compound 4: 1.1-fold (0.02 log units) above; low and high end bracket the measured number.
By their numbers in this assay, from the lowest: compounds 1, 2 and 4 (each within the scatter of the next); then compound 3.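

Taking the chloro from the 3,4-dichlorophenyl group gives a 2.4-fold lower number from compound 3 to compound 4 (0.38 log units; beyond the scatter), whereas taking one from the 2,3-dichlorophenyl group gives only a 1.2-fold higher number from compound 2 to compound 4 (0.07 log units; within the scatter), and exchanging 4-chlorophenyl for 3-chlorophenyl gives a 1.6-fold higher number from compound 1 to compound 4 (0.20 log units; within the scatter). The weaker number of compound 3 therefore goes with the 3,4-dichlorophenyl pattern, not with a single chloro at either place. The effect of a chloro on this aromatic carbon depends on what else the ring carries: the same change on two cores in this assay, a 3.8-fold higher number (0.57 log units; beyond the scatter) from compound 1 to compound 3 and a 1.2-fold lower number (0.07 log units; within the scatter) from compound 4 to compound 2, 4.4-fold (0.65 log units) apart, beyond the scatter of two such steps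

Going by these compounds, whether a fluoro or a methoxy group at this place would behave like the chloro stays open. So does the value of the unsubstituted phenyl ring on the shared core.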